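The source may report more compounds than this note shows. Statements on the series, on what has been measured and on what is new or still open speak of the compounds shown alone.

Measured so far in an assay on isolated protein for displacement of a labelled ligand from 5-hydroxytryptamine receptor 6 (Homo sapiens); a higher number here means a weaker inhibitor, a lower number a stronger inhibitor:
compound 1, `NC[C@@H]1CCCc2cc(S(=O)(=O)c3cccc(F)c3)ccc21`: 0.0794 nM
compound 2, `NC[C@@H]1CCCc2cc(S(=O)(=O)Cc3ccccc3)ccc21`: 158 nM
compound 3, `NC[C@@H]1CCCc2cc(S(=O)(=O)c3cn[nH]c3)ccc21`: 2 nM

Compound 1 holds the lowest number of the three. The nearest to it is compound 3, reached by a 25-fold higher number from compound 1 to compound 3 (1.40 log units; beyond the scatter); the furthest is compound 2, reached by a 2000-fold higher number from compound 1 to compound 2 (3.30 log units; beyond the scatter). Between the other two the step is a 79-fold lower number from compound 2 to compound 3 (1.90 log units; beyond the scatter). All three steps concern only the group on the sulfonyl sulfur; the aminomethyl group of the shared core is the same in every measured compound.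

Compound 4, `CN(C)S(=O)(=O)NC[C@@H]1CCCc2cc(S(=O)(=O)c3cccc(F)c3)ccc21`, differs from compound 1 in another place: dimethylsulfamoyl in place of hydrogen on an amine nitrogen. Within the data shown here, none of the measured steps touches this part of the core, so no measured step bears directly on the change; the measured steps show only that single exchanges have moved the number by large amounts. For a change at the amine nitrogen the data give no anchor, and the working expectation is a higher number than for compound 1, a step of a 380-fold higher number from compound 1 to compound 4 (2.58 log units; beyond the scatter), held with wide uncertainty. Compound 4 is expected to give 30 nM, with a range from 2 nM to 500 nM.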

Compound 4, inhibition constant: 2 nM
Compound 4: the middle estimate sits 15-fold (1.18 log units) above what was measured; the range from low to high includes it.
By their numbers in this assay, from the lowest: compound 1; then compounds 3 and 4 (each within the scatter of the next); then compound 2.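

In this assay, among these compounds, the step at the amine nitrogen, a 25-fold higher number from compound 1 to compound 4 (1.40 log units; beyond the scatter), is the first measured change outside the group on the sulfonyl sulfur, and it shows that this position also moves the number by a large amount. The same result shows that the position accepts dimethylsulfamoyl, with 6 heavy atoms and no net charge, while compound 4 still gives 2 nM, so replacing hydrogen on this nitrogen does not abolish binding in this assay. No measurement available here explains the size of this step.

On these data alone, with a single substituent on the amine nitrogen, it remains open whether the step belongs to dimethylsulfamoyl in particular or to substitution at this nitrogen in general; a methyl group, an acetyl group or a methanesulfonyl group there would separate these readings. Also open, as far as these compounds go, is whether dimethylsulfamoyl gives a step of similar size when the sulfonyl sulfur carries benzyl or 1H-pyrazol-4-yl, as in compound 2 and compound 3, rather than 3-fluorophenyl.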